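Carboxyphenyl Position on Two Fused Cores in Receptor Binding

This account rests on a few compounds, and the source may have more. Where it says the series, first, only, none or still open, it means among the compounds named here.

Compound 1, `CC(C)c1onc(-c2c(Cl)cccc2Cl)c1COc1ccc2sc(-c3cccc(C(=O)O)c3)cc2c1`: 55 nM
Compound 2, `CC(C)c1onc(-c2c(Cl)cccc2Cl)c1COc1ccc2sc(-c3ccc(C(=O)O)cc3)cc2c1`: 280 nM
Compound 3, `CC(C)c1onc(-c2c(Cl)cccc2Cl)c1COc1ccc2cc(-c3cccc(C(=O)O)c3)ccc2c1`: 110 nM

Three compounds were measured in an assay on isolated protein for binding affinity to Bile acid receptor (Homo sapiens), read by FRET; on this read-out higher numbers stand for an effect only at larger amounts of compound and lower numbers for an effect already at smaller amounts. In this assay compound 1 gives 55 nM, compound 2 gives 280 nM and compound 3 gives 110 nM. Compound 1 and compound 2 share one core and differ by 4-carboxyphenyl in place of 3-carboxyphenyl on an aromatic carbon; this change gave a 5.1-fold higher number from compound 1 to compound 2 (0.71 log units; beyond the scatter). Compound 3 carries a different core, and the difference between the two cores is not broken down here. Compound 3 and compound 1 lie within the scatter of each other, while compound 3 and compound 2 are separated by a step beyond it.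

Compound 4, `CC(C)c1onc(-c2c(Cl)cccc2Cl)c1COc1ccc2cc(-c3ccc(C(=O)O)cc3)ccc2c1`, has not yet been measured. It differs from compound 3 by 4-carboxyphenyl in place of 3-carboxyphenyl on an aromatic carbon. This is the same kind of change as that from compound 1 to compound 2, but not the same: there the group sat on a five-membered aromatic ring with one sulfur, next to the ring sulfur, whereas here it sits on a six-membered aromatic ring of carbon only, meta to a fused ring and para to a fused ring.

For compound 4 the step is expected to be a 4.1-fold higher number from compound 3 to compound 4 (0.61 log units; beyond the scatter), resting on the earlier step of a 5.1-fold higher number from compound 1 to compound 2 (0.71 log units; beyond the scatter), with the different place leaving room for a smaller or larger step. Compound 4 is therefore estimated at 450 nM, between 150 nM and 1500 nM.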

Compound 4, half-maximal effective concentration: 440 nM
Compound 4: middle estimate off by 1.0-fold (0.01 log units), on the high side; the measured number falls inside the stated range.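

In this assay, 4-carboxyphenyl in place of 3-carboxyphenyl on the second core gave a 4.0-fold higher number from compound 3 to compound 4 (0.60 log units; beyond the scatter), and this step agrees with the one seen earlier on the core of compound 1: the same change on two cores in this assay, a 5.1-fold higher number (0.71 log units; beyond the scatter) from compound 1 to compound 2 and a 4.0-fold higher number (0.60 log units; beyond the scatter) from compound 3 to compound 4, 1.3-fold (0.10 log units) apart, within the scatter of two such steps Within these two pairs, then, the change carried from one core to the other with its direction kept and its size unchanged within the scatter, and on each core the compound with 3-carboxyphenyl gave the lower number. Going by these compounds alone, this rests on only two cores and a single read-out on isolated protein, so it does not show that the step would hold on any further core or in another kind of assay, and it does not explain why the two positions differ.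

The compounds shown leave open what would happen if the carboxylic acid itself gave way to an amide, a tetrazole or a methyl ester, since all four compounds carry the carboxylic acid directly on the phenyl ring. They also leave open whether a longer chain, such as a methylene or an ethylene link from that phenyl ring to the carboxylic acid, would keep the same preference for 3-carboxyphenyl over 4-carboxyphenyl on either core.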